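This account rests on a few compounds, and the source may have more. Where it says the series, first, only, none or still open, it means among the compounds named here.

Compound 1 `C[Se]/C(=N\C(=O)c1cccs1)NC(=O)c1cccs1` and compound 2 `CS/C(=N\C(=O)c1cccs1)NC(=O)c1cccs1` share one core and differ in a single group. In a functional assay on HepG2 cells (Homo sapiens) for cytotoxicity, read by MTT assay, with a stated time of 72 h (on this read-out higher numbers stand for weaker inhibition of growth and lower numbers for stronger inhibition of growth), compound 1 gives 630 nM. Compound 2 reaches only the limit of this assay, > 100000 nM, so no number is known for it. The change from compound 2 to compound 1 is a group of 2 heavy atoms (1 carbon, 1 selenium; no ring) in place of a group of 2 heavy atoms (1 carbon, 1 sulfur; no ring), on a carbon with a double bond to nitrogen and it brings an at least 150-fold lower number from compound 2 to compound 1 (2.20 log units; beyond the scatter); the starting point is the limit of > 100000 nM in this assay, at which 1 of the 3 values shown sits, so only a bound on the size of this step is available. Compound 3 `CS/C(=N\C(=O)c1cc(-c2ccccc2)nc2ccccc12)NC(=O)c1cc(-c2ccccc2)nc2ccccc12` carries the methylsulfanyl group on another core; how its core differs from the core of compound 2 is not broken down here. In this assay compound 3 gives 6240 nM. Compound 4 `C[Se]/C(=N\C(=O)c1cc(-c2ccccc2)nc2ccccc12)NC(=O)c1cc(-c2ccccc2)nc2ccccc12` has not yet been measured; it stands to compound 3 as compound 1 stands to compound 2, by the same change, (a group of 2 heavy atoms (1 carbon, 1 selenium; no ring) in place of a group of 2 heavy atoms (1 carbon, 1 sulfur; no ring), on a carbon with a double bond to nitrogen). For the measured compounds named here, compound 4 is expected to show a 62-fold lower number from compound 3 to compound 4 (1.80 log units; beyond the scatter), a step in the same direction as the one from compound 2 to compound 1 but set smaller, as that earlier step is known only as a bound. In this assay compound 4 is estimated at 100 nM, with a range from 15 nM to 1000 nM.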

Compound 4, concentration for 50% growth inhibition: 4540 nM
For compound 4 the middle estimate is 45-fold (1.66 log units) below the measured one, outside the stated range (above it).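

In this assay, putting the selenium-bearing group in place of methylsulfanyl on the core of compound 3 gives a 1.4-fold lower number from compound 3 to compound 4 (0.14 log units; within the scatter), so on this core the two groups cannot be told apart. The change therefore does not carry over in size from one core to the other, and the large step seen on the core of compound 1 cannot be taken as a rule for this series: the same change on two cores in this assay, an at least 150-fold lower number (2.20 log units; beyond the scatter) from compound 2 to compound 1 and a 1.4-fold lower number (0.14 log units; within the scatter) from compound 3 to compound 4, at least 110-fold (2.06 log units) apart, beyond the scatter of two such steps. The true size of that gap stays unknown, and the two pairs give no reason for it, as compound 2 stands at a limit and not at a number: the limit of > 100000 nM in this assay, at which 1 of the 4 values shown sits.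

With only two cores shown, it remains open which of them is the more typical case for this change. Also open, on these data alone, is whether a longer chain on the selenium, such as an ethyl group, would follow the same course on either core.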